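The source may hold more compounds than are shown below. What is called first, only, known or untested is meant among the compounds shown, and "the series" means these compounds.

Compound 1 `COc1ccc(CNc2nc([Se]C)nc3ccccc23)cc1` stands at the top edge of the numbers shown: in a functional assay on CCRF-CEM cells (Homo sapiens) for cytotoxicity, read by MTT assay, with a stated time of 72 h (on this read-out lower numbers stand for stronger inhibition of growth and higher numbers for weaker inhibition of growth), compound 1 gives > 100000 nM, which is a limit of the assay and not a number. Compound 2 `COc1ccc(CNc2nc(SC)nc3ncccc23)cc1` gives > 100000 nM in this assay, again only a limit. Compound 3 `C[Se]c1nc(NCc2ccccc2)c2ccccc2n1` gives 61600 nM in this assay. Among the compounds with values here, the single measured step runs an at least 1.6-fold lower number from compound 1 to compound 3 (0.21 log units; that floor lies within the scatter), and its floor rests on (the limit of > 100000 nM in this assay, at which 2 of the 3 values shown sit). Compound 4 `COc1ccc(CNc2nc(SC)nc3ccccc23)cc1` is the counterpart of compound 1 with a group of 2 heavy atoms (1 carbon, 1 sulfur; no ring) in place of a group of 2 heavy atoms (1 carbon, 1 selenium; no ring), on an aromatic carbon. Within the data shown here, no measured step isolates this exchange. Compound 2, the other methylsulfanyl compound, reaches only a limit. Among the measured compounds shown here, with compound 1 itself unresolved and no step pointing either way, the expectation for compound 4 in this assay is no change beyond the scatter, a number no higher from compound 1 to compound 4 (the limit leaves the size open). Compound 4 is therefore estimated at 100000 nM, with a range from 40000 nM to 300000 nM in this assay, and it is expected most likely to be reported again only as a limit.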

Compound 4, concentration for total growth inhibition: > 100000 nM
Compound 4 ended at the assay's limit (the forecaster's own chance of this, stated with the estimate: 65%); the middle value sits exactly at the limit.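

Within the data shown here, compound 1 and compound 4 both end at a limit in this assay, not at a number, so no step between them can be read: the limit of > 100000 nM in this assay, at which 3 of the 4 values shown sit. The compounds shown leave open whether methylsulfanyl in place of the selenium-bearing group changes growth inhibition at all.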